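The source may report more compounds than this note shows. Statements on the series, on what has been measured and on what is new or still open speak of the compounds shown alone.

Of the compounds shown here, three sharing one core have been measured in an assay on cells for displacement of a labelled ligand from corticotropin-releasing factor receptor 1 (Homo sapiens), with a stated time of 100 min; a lower number here means a stronger inhibitor, a higher number a weaker inhibitor. Compound 1 `C=CCN(CCC)Cc1c(C(F)(F)F)nc2n(-c3c(C)cc(C)cc3C)c(Cl)cn12` gives 4.5 nM, compound 2 `CCN(Cc1c(C(F)(F)F)nc2n(-c3c(C)cc(C)cc3C)c(Cl)cn12)CC1CCC1` gives 16 nM, and compound 3 `CCN(Cc1ccccc1)Cc1c(C(F)(F)F)nc2n(-c3c(C)cc(C)cc3C)c(Cl)cn12` gives 350 nM, the highest of the three numbers and therefore the weakest inhibitor here, since both a 78-fold higher number from compound 1 to compound 3 (1.89 log units; beyond the scatter) and a 22-fold higher number from compound 2 to compound 3 (1.34 log units; beyond the scatter) lie beyond the scatter.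

Compound 4 `Cc1cc(C)c(-n2c(Cl)cn3c(CN(C)Cc4ccco4)c(C(F)(F)F)nc23)c(C)c1` differs from compound 3 in one place: ((furan-2-yl)methyl)(methyl)amino in place of benzyl(ethyl)amino on a saturated chain carbon bound to an aromatic carbon. Of the measured steps, a 22-fold higher number from compound 2 to compound 3 (1.34 log units; beyond the scatter) bears most directly on this, as it shows that an aromatic ring on the carbon bound to the amine nitrogen costs a large amount compared with a saturated cyclobutyl ring; a 78-fold higher number from compound 1 to compound 3 (1.89 log units; beyond the scatter) points the same way. Compound 4 keeps an aromatic ring in that position, though a smaller five-membered one, and carries a methyl rather than an ethyl on the nitrogen. Because of a 22-fold higher number from compound 2 to compound 3 (1.34 log units; beyond the scatter) only a small recovery is expected, so compound 4 is estimated to give 150 nM, within 40 nM to 600 nM, an expected 2.3-fold lower number from compound 3 to compound 4 (0.37 log units; beyond the scatter).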

Compound 4, inhibition constant: 180 nM
Estimate against measurement, compound 4: 1.2-fold (0.08 log units) below, within the range that was stated.
By their numbers in this assay, from the lowest: compound 1; then compound 2; then compounds 4 and 3 (each within the scatter of the next).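

In this assay the exchange of benzyl(ethyl)amino for ((furan-2-yl)methyl)(methyl)amino gives a 1.9-fold lower number from compound 3 to compound 4 (0.29 log units; within the scatter) and so does not separate compound 4 from compound 3, even though the six-membered aromatic ring gives way to a five-membered one with a hetero atom. Both an 11-fold higher number from compound 2 to compound 4 (1.05 log units; beyond the scatter) and a 40-fold higher number from compound 1 to compound 4 (1.60 log units; beyond the scatter) show that compound 4 remains well apart from the two compounds without an aromatic ring in this group, so among these four compounds the large gap is not confined to the benzyl group. Nothing measured here explains this result.

From the compounds shown here alone, the ring and the group on the nitrogen changed together, so the share of each remains open. Also open, going by these compounds, is how a saturated ring with oxygen, such as tetrahydrofuran-2-yl, would behave in place of the furan-2-yl ring.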